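A few compounds are considered here, and "the series" means these few. Any claim that something is new, unique, unknown or untested is made for them only; others in the source may bear on it.

Compound 1 `CN1C(=O)C2(C(C#N)=C(N)Oc3cc4oc(-c5ccccc5)cc(=O)c4c(O)c32)c2ccccc21` — > 50000 nM
Compound 2 `Cc1ccc2c(c1)C1(C(=O)N2C)C(C#N)=C(N)Oc2cc3oc(-c4ccccc4)cc(=O)c3c(O)c21` — > 50000 nM
Compound 3 `CN1C(=O)C2(C(C#N)=C(N)Oc3cc4oc(-c5ccccc5)cc(=O)c4c(O)c32)c2cc(Cl)ccc21` — 21400 nM

In a functional assay on PC-3 cells (Homo sapiens) for antiproliferative activity, read by MTT assay, with a stated time of 48 h (a lower number here means a stronger inhibitor, a higher number a weaker inhibitor), compound 1 gives > 50000 nM, which is a limit of the assay rather than a number. Compound 2 likewise gives > 50000 nM, also a limit. Within the data shown here, compound 3 gives 21400 nM, the only true number among the three, and so it stands as the sole anchor here. The two readable steps are an at least 2.3-fold lower number from compound 1 to compound 3 (0.36 log units; beyond the scatter) and an at least 2.3-fold lower number from compound 2 to compound 3 (0.36 log units; beyond the scatter); the step that the two limits leave unreadable from compound 1 to compound 2 cannot be read, because of the limit of > 50000 nM in this assay, at which 2 of the 3 values shown sit.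

Compound 4 `CN1C(=O)C2(C(C#N)=C(N)Oc3cc4oc(-c5ccccc5)cc(=O)c4c(O)c32)c2cc(Br)ccc21` differs from compound 3 by bromo in place of chloro on an aromatic carbon. Among the measured compounds shown here, no measured step swaps one halogen for another, so the expectation rests on compound 3 alone: an estimated 15000 nM, within 5000 nM to 45000 nM, an expected step of a 1.4-fold lower number from compound 3 to compound 4 (0.15 log units; within the scatter).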

Compound 4, half-maximal inhibitory concentration: 20300 nM
Beside the measured number, compound 4's estimate is 1.4-fold (0.13 log units) below it, and the stated range covers the measured number.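

At this position, chloro and bromo cannot be told apart in this assay: the swap gives a 1.1-fold lower number from compound 3 to compound 4 (0.02 log units; within the scatter). Bromo also keeps the gain over methyl and hydrogen, with an at least 2.4-fold lower number from compound 2 to compound 4 (0.39 log units; beyond the scatter) and an at least 2.4-fold lower number from compound 1 to compound 4 (0.39 log units; beyond the scatter), so among these compounds the gain is not tied to chloro alone. Both of these steps give only a minimum size: the limit of > 50000 nM in this assay, at which 2 of the 4 values shown sit.

The step between hydrogen and methyl cannot be read. On these data alone, whether fluoro, a methoxy group or an amine at this position would read like chloro and bromo stays open.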